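Compound 4: ethyl on the piperazine of compound 1

The compounds below may be only part of what the source reports. "The series", "measured", "known", "first", "only" and "open" are said of these compounds alone.

In an ADME assay on microsomes from liver (Mus musculus) for metabolic stability, read by LC-MS, with a stated time of 10 min, tested at 0.5 uM (a higher number here means that more of the compound is left, a lower number that less of the compound is left), compound 1 (`c1ccc2c(c1)CN[C@@H](CN(CCCN1CCNCC1)[C@H]1CCCc3cccnc31)C2`) stands at 92% and is the highest of three numbers, ahead of compound 3 (`c1cnc2c(c1)CCC[C@@H]2N(CCCN1CCNCC1)Cc1cc2ccccc2cn1`) at 74% and compound 2 (`c1ccc2c(c1)CN[C@@H](CN(CC[C@@H]1CCCNC1)[C@H]1CCCc3cccnc31)C2`) at 23% so far. Compound 4 (`CCN1CCN(CCCN(C[C@H]2Cc3ccccc3CN2)[C@H]2CCCc3cccnc32)CC1`) carries ethyl in place of hydrogen on an amine nitrogen in a ring. Among the compounds with values here, two measured steps bear on it only loosely. Piperidin-3-yl in place of (piperazin-1-yl)methyl gave a number 69 percentage points lower from compound 1 to compound 2 (beyond the scatter) and isoquinolin-3-yl in place of 1,2,3,4-tetrahydroisoquinolin-3-yl gave a number 18 percentage points lower from compound 1 to compound 3 (beyond the scatter) as the smaller change. Neither puts a group on this nitrogen, so no direct measure exists. A modest fall in this assay is expected, nearer the smaller step, and the estimate means a number 17 percentage points lower from compound 1 to compound 4 (beyond the scatter) as the expected change. Compound 4 is expected at 75% with an estimated range from 50% to 92% around it.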

Compound 4, percent of the compound remaining: 19%
For compound 4 the middle estimate is 56 percentage points above the measured one; the whole stated range lies above it.
By their numbers in this assay, from the lowest: compounds 4 and 2 (each within the scatter of the next); then compound 3; then compound 1.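

Ethyl on the ring amine nitrogen of the piperazine, a change of only 2 heavy atoms, gives a number 73 percentage points lower from compound 1 to compound 4 (beyond the scatter) in this assay, so this position tolerates even a small substituent poorly. (4-Ethylpiperazin-1-yl)methyl in place of piperidin-3-yl gives a number 4 percentage points lower from compound 2 to compound 4 (within the scatter), which places this small addition level with the much larger side-chain replacement. Nothing available accounts for the loss.

On these data alone, whether methyl, acetyl or a longer chain on this nitrogen brings the same loss stays open. Also open, as far as these compounds go, is whether ethyl here has the same effect on compound 3, which carries isoquinolin-3-yl.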